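Adding a second chloro to the urea aryl ring

This account rests on a few compounds, and the source may have more. Where it says the series, first, only, none or still open, it means among the compounds named here.

Compound 1 `CN(C)CCNc1nc(-c2ccc(NC(=O)Nc3ccc(Cl)cc3Cl)cc2)nc2c(Cl)c(Cl)sc12` gives 3460 nM in a functional assay on MKN-45 cells (Homo sapiens) for cytotoxicity, read by MTT assay, with a stated time of 72 h; on this read-out lower numbers stand for stronger inhibition and higher numbers for weaker inhibition.
Compound 2 `CCN(CC)CCCNc1nc(-c2ccc(NC(=O)Nc3ccc(Cl)cc3Cl)cc2)nc2c(Cl)c(Cl)sc12` gives 5720 nM in this assay.
Compound 3 `CCN(CC)CCNc1nc(-c2ccc(NC(=O)Nc3ccccc3Cl)cc2)nc2c(Cl)c(Cl)sc12` gives 1130 nM in this assay.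

Compound 3 has the lowest number of the three, and compound 1 stands beyond the scatter above it. Compound 4 `CCN(CC)CCNc1nc(-c2ccc(NC(=O)Nc3ccc(Cl)cc3Cl)cc2)nc2c(Cl)c(Cl)sc12` is compound 3 with chloro in place of hydrogen on an aromatic carbon. Within the data shown here, the only measured step, a 1.7-fold higher number from compound 1 to compound 2 (0.22 log units; within the scatter), alters the amine chain and leaves the chlorinated ring untouched, so it does not bear directly on this change; it does show that compound 4 and compound 1, which share the dichlorophenyl urea, differ by a kind of change that stayed within the scatter. Compound 4 is therefore expected to move toward the number of compound 1, a rise of a 2.7-fold higher number from compound 3 to compound 4 (0.42 log units; beyond the scatter). The estimate for compound 4 is 3000 nM, between 1200 nM and 7500 nM.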

Compound 4, half-maximal inhibitory concentration: 1770 nM
Compound 4: the middle estimate sits 1.7-fold (0.23 log units) above what was measured, and the stated range covers the measured number.
By their numbers in this assay, from the lowest: compounds 3, 4, 1 and 2 (each within the scatter of the next, the first and the last beyond it).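

In this assay, chloro in place of hydrogen, para to a large group, gives a 1.6-fold higher number from compound 3 to compound 4 (0.19 log units; within the scatter), so on this 2-chlorophenyl urea the added chloro shifts the number no more than the usual scatter. Among these compounds, with the 2,4-dichlorophenyl urea held fixed, the amine chain gives the only step beyond the scatter, a 3.2-fold lower number from compound 2 to compound 4 (0.51 log units; beyond the scatter), whereas a 2.0-fold lower number from compound 1 to compound 4 (0.29 log units; within the scatter) stays within it. No measurement shown here gives a reason for these steps. Left open is how fluoro or methoxy in place of this chloro, or piperidine in place of diethylamino, would read in this assay.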